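This account rests on a few compounds, and the source may have more. Where it says the series, first, only, none or still open, it means among the compounds named here.

Compound 1 `O=S(=O)(Nc1cc(-c2ccc3ncoc3c2)cnc1Cl)c1ccc(F)cc1` gives > 12000 nM
Compound 2 `Nc1nc2ccc(-c3cnc(Cl)c(NS(=O)(=O)c4ccc(F)cc4)c3)cc2[nH]1` gives > 12000 nM
Compound 3 `Nc1nc2ccc(-c3cnc(Cl)c(NS(=O)(=O)c4ccc(F)cc4)c3)cc2s1` gives 44 nM

Of the compounds shown here, three have been measured in an assay on U-87MG ATCC cells for inhibition of RAC-alpha serine/threonine-protein kinase (Homo sapiens), read by AlphaScreen, with a stated time of 2 h; a higher number here means a weaker inhibitor, a lower number a stronger inhibitor. Compound 1 `O=S(=O)(Nc1cc(-c2ccc3ncoc3c2)cnc1Cl)c1ccc(F)cc1` reaches only a limit of the assay in this assay, > 12000 nM, so no number is known for it. The same holds for compound 2 `Nc1nc2ccc(-c3cnc(Cl)c(NS(=O)(=O)c4ccc(F)cc4)c3)cc2[nH]1`, whose value in this assay, > 12000 nM, is also a limit. Compound 3 `Nc1nc2ccc(-c3cnc(Cl)c(NS(=O)(=O)c4ccc(F)cc4)c3)cc2s1`, by contrast, gives a measured value of 44 nM in this assay. Compound 1 therefore stands at the limit of > 12000 nM in this assay, at which 2 of the 3 values shown sit, and nothing places it more precisely than that.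

The next compound, compound 4 `O=S(=O)(Nc1cc(-c2ccc3nc[nH]c3c2)cnc1Cl)c1ccc(F)cc1`, is not yet measured. It differs from compound 1 in one place: 1H-benzimidazol-6-yl in place of 1,3-benzoxazol-6-yl on an aromatic carbon. Among the measured compounds shown here, no step between two measured compounds matches this change, so its size is not known from the data. Because compound 1 sits at the limit of > 12000 nM in this assay, at which 2 of the 3 values shown sit, together with compound 2, a change at this place has so far given no measurable value, and the expectation for compound 4 is that it stays near the limit, with no step beyond the scatter. Compound 4 is thus expected to give about 12000 nM in this assay, with a range from 3000 nM to 40000 nM, which means an expected step of a number no higher from compound 1 to compound 4 (the limit leaves the size open).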

Compound 4, half-maximal inhibitory concentration: > 12000 nM
Compound 4: only a limit was reported; the forecaster's own chance of this, stated with the estimate: 70%; the middle value sits exactly at the limit.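

In this assay compound 4 gives > 12000 nM, which is a limit and not a number. The steps from compound 1 and from compound 2 to compound 4 therefore cannot be read, since each pair has only limits: the limit of > 12000 nM in this assay, at which 3 of the 4 values shown sit.

The compounds shown leave open how far compound 1, compound 2 and compound 4 truly lie from that limit.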